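The source may report more compounds than this note shows. Statements on the series, on what has been measured and on what is new or still open speak of the compounds shown alone.

Measured compounds:
compound 1 `Nc1nc(NCc2ccccc2)c2ncn(/C=C3/CC3(CO)CO)c2n1`, a limit in an ADME assay on CCRF-HSB-2 cells (Homo sapiens) for cytotoxicity, with a stated time of 7 days; on this read-out lower numbers stand for higher toxicity in this test and higher numbers for lower toxicity in this test: > 20000 nM
compound 2 `Nc1nc(NC2CC2)c2ncn(/C=C3/CC3(CO)CO)c2n1`, a limit in this assay: > 20000 nM

Compound 2 stands at the limit of this assay, and that is all the numbers show of it; the value given for compound 2, > 20000 nM, is a limit, not a measured number. Both values shown sit at the same place, (the limit of > 20000 nM in this assay, at which 2 of the 2 values shown sit). For the measured compounds named here, the one measured step, a step that the two limits leave unreadable from compound 1 to compound 2, is the only step touching the nitrogen concerned, and its size cannot be read from two limits.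

Compound 3 `CCCCNc1nc(N)nc2c1ncn2/C=C1/CC1(CO)CO` differs from compound 2 by butyl in place of cyclopropyl on a nitrogen on an aromatic ring. No readable step bears on this change, so the expectation for compound 3 rests on both measured compounds sitting at the limit. The step that the limit leaves unreadable from compound 2 to compound 3 is therefore expected to be none beyond the scatter. Compound 3 is estimated at 30000 nM, within 15000 nM to 100000 nM, most likely again reported only as a limit.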

Compound 3, half-maximal cytotoxic concentration: > 20000 nM
Compound 3 was reported as a limit; the forecaster's own chance of this, stated with the estimate: 85%; the middle value does not contradict the limit.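

In this assay compound 3 gives > 20000 nM, which is a limit, not a number. No step among compound 1, compound 2 and compound 3 can be read, and all their values sit at one place: the limit of > 20000 nM in this assay, at which 3 of the 3 values shown sit.

The compounds shown leave open how benzyl, cyclopropyl and butyl on the nitrogen truly differ in this assay.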